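Methylsulfonyl in Place of Carbamoyl: Expectation for Compound 4

The source may report more compounds than this note shows. Statements on the series, on what has been measured and on what is new or still open speak of the compounds shown alone.

Three measured compounds share one core: compound 1 `CCOc1ccc(CNC(=O)c2ccc(C(C)(C)C)cc2)cc1`, compound 2 `CC(C)(C)c1ccc(C(=O)NCc2ccc(C(N)=O)cc2)cc1` and compound 3 `CC(C)(C)c1ccc(C(=O)NCc2ccc(NC(=O)C(F)(F)F)cc2Cl)cc1`. In an assay on HeLa cells with Bile acid receptor (Homo sapiens) as the target, read by a luciferase reporter, with a stated time of 24 h (on this read-out higher numbers stand for an effect only at larger amounts of compound and lower numbers for an effect already at smaller amounts), compound 1 gives 160 nM, compound 2 gives 3800 nM and compound 3 gives 14 nM. Compound 2 therefore stands at the highest number of the three, beyond the scatter from both others. Going by the values given here, the only measured single step, a 24-fold higher number from compound 1 to compound 2 (1.38 log units; beyond the scatter), concerns a different exchange at the same position. Compound 4 `CC(C)(C)c1ccc(C(=O)NCc2ccc(S(C)(=O)=O)cc2)cc1` differs from compound 2 by methylsulfonyl in place of carbamoyl on an aromatic carbon. Among the compounds with values here, no measured step addresses this exchange, so the account expects at most a modest move toward lower numbers in this assay, an estimated step of a 1.9-fold lower number from compound 2 to compound 4 (0.28 log units; within the scatter). For compound 4 the estimate is 2000 nM, with a range from 500 nM to 8000 nM.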

Compound 4, half-maximal effective concentration: 3800 nM
Estimate against measurement, compound 4: 1.9-fold (0.28 log units) below; low and high end bracket the measured number.
By their numbers in this assay, from the lowest: compound 3; then compound 1; then compounds 2 and 4 (each within the scatter of the next).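

With this assay as the read-out, the exchange gives no change at the digits printed from compound 2 to compound 4 (within the scatter) and so shows that methylsulfonyl and carbamoyl cannot be told apart at this position, although one group carries a hydrogen-bond donor and the other carries none. Measured against ethoxy, the same group gives a 24-fold higher number from compound 1 to compound 4 (1.38 log units; beyond the scatter) and thereby matches the carbamoyl step in size, so two different replacements of ethoxy now sit at one level. No evidence at hand bears on the reason for this result. The compounds shown leave open whether an amine, a carboxylic acid or a longer alkoxy chain at this position would stay at this level or move toward the number of compound 1.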